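Hydrogen in place of fluoro on compound 2

The source may report more compounds than this note shows. Statements on the series, on what has been measured and on what is new or still open speak of the compounds shown alone.

In a functional assay on IMR-32 cells (Homo sapiens) for cytotoxicity, read by sulforhodamine B assay, with a stated time of 48 h (a higher number here means a weaker inhibitor, a lower number a stronger inhibitor), compound 1 (`C=CCOc1ccc(F)cc1C(=O)c1cccnc1`) gives 91000 nM and compound 2 (`O=C(c1cccnc1)c1cc(F)ccc1O`) gives 6210 nM as the lower of the two numbers. For the measured compounds named here, the one measured step, a 15-fold lower number from compound 1 to compound 2 (1.17 log units; beyond the scatter) with hydrogen in place of allyl on an oxygen on an aromatic ring, is large and beyond the scatter. Compound 3 (`O=C(c1cccnc1)c1ccccc1O`) awaits measurement. Its difference from compound 2 is hydrogen in place of fluoro on an aromatic carbon and in words it is hydrogen in place of fluoro on an aromatic carbon, para to a hydroxy group. Both measured compounds carry the fluoro group, so the data hold no direct comparison for this exchange, and the measured step gives no size for it. Compound 3 keeps the hydroxy group of compound 2 (6210 nM), so its number is expected to stay near that value. No step beyond the scatter is expected in this assay and a slightly higher number is the likelier direction. The expected step is a 1.2-fold higher number from compound 2 to compound 3 (0.08 log units; within the scatter) in this estimate. The estimated value for compound 3 is 7500 nM with an expected range from 2500 nM to 22000 nM as its ends.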

Compound 3, half-maximal inhibitory concentration: 33700 nM
Compound 3: middle estimate off by 4.5-fold (0.65 log units), on the low side; the measured number lies above the stated range.
By their numbers in this assay, from the lowest: compound 2; then compound 3; then compound 1.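

In this assay the aromatic carbon para to a hydroxy group proves to be a position that matters: hydrogen in place of fluoro there gives a 5.4-fold higher number from compound 2 to compound 3 (0.73 log units; beyond the scatter) and this modest step lies beyond the scatter. For the compounds shown here, until now, the only measured change was on the oxygen, with a 15-fold lower number from compound 1 to compound 2 (1.17 log units; beyond the scatter), so the new step is the first sign that a second place on the shared core also moves the number, and that the fluoro group of compound 2 goes with the lower value of this pair. No measurement on hand explains this step, so it stands as an observation on these two compounds alone.

The compounds shown leave open whether another group on the same aromatic carbon, such as chloro, methoxy or an amine, gives a number nearer that of compound 2 or that of compound 3. They also leave open whether the exchange of fluoro for hydrogen keeps its size when the oxygen carries allyl rather than hydrogen.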